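Shifting the methyl group of compound 3

The compounds below may be only part of what the source reports. "The series", "measured", "known", "first", "only" and "open" are said of these compounds alone.

In a functional assay on A549 cells (Homo sapiens) for antiproliferative activity, read by MTT assay, with a stated time of 48 h (a higher number here means a weaker inhibitor, a lower number a stronger inhibitor), compound 1 `COc1cc(-c2cccc3nc(-c4ccccc4)oc23)cc(OC)c1OC` gives 20300 nM, compound 2 `COc1ccc(-c2nc3cccc(-c4cc(OC)c(OC)c(OC)c4)c3o2)cc1F` gives 1800 nM, and compound 3 `COc1cc(-c2cccc3nc(-c4ccc(C)cc4)oc23)cc(OC)c1OC` gives 680 nM, the lowest of the three numbers. Compound 4 `COc1cc(-c2cccc3nc(-c4cccc(C)c4)oc23)cc(OC)c1OC` has 3-methylphenyl in place of 4-methylphenyl on an aromatic carbon. The most relevant evidence is the large 30-fold lower number from compound 1 to compound 3 (1.47 log units; beyond the scatter), seen when a methyl group is added. The modest 2.6-fold lower number from compound 2 to compound 3 (0.42 log units; beyond the scatter) shows that this substituent choice also matters. Within the data shown here, no measured compound carries 3-methylphenyl, so how much of that large step survives is unknown. Part of it is expected to be lost, and the expected change is a 2.2-fold higher number from compound 3 to compound 4 (0.34 log units; beyond the scatter). For compound 4, the estimated value is 1500 nM, with an expected range of 500 nM to 6000 nM.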

Compound 4, half-maximal inhibitory concentration: 16700 nM
Compound 4: middle estimate off by 11-fold (1.05 log units), on the low side; the measured number lies above the stated range.
By their numbers in this assay, from the lowest: compound 3; then compound 2; then compounds 4 and 1 (each within the scatter of the next).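

Moving the methyl from 4-methylphenyl to 3-methylphenyl gives a 25-fold higher number from compound 3 to compound 4 (1.39 log units; beyond the scatter) in this assay, so the gain in compound 3 depends on where the methyl sits, not merely on its presence. The 3-fluoro-4-methoxyphenyl group also compares well with 3-methylphenyl, with a 9.3-fold higher number from compound 2 to compound 4 (0.97 log units; beyond the scatter), while a 1.2-fold lower number from compound 1 to compound 4 (0.08 log units; within the scatter) means that 3-methylphenyl cannot be told apart from plain phenyl. Nothing available here explains this dependence on position. Still open, on these data alone, is whether an ethyl group or an amine on the 4-position of the phenyl ring would keep the gain seen with methyl.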